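Swapping Amino for Methoxymethyl in a Glycine Transporter Inhibitor

A few compounds are considered here, and "the series" means these few. Any claim that something is new, unique, unknown or untested is made for them only; others in the source may bear on it.

compound 1: `Cc1nnc(-c2ccc(-c3ccccn3)cc2)n1-c1ccccc1F`, 860 nM
compound 2: `CCc1nnc(-c2ccc(-c3ccccc3)cc2)n1-c1cccc(N)c1C`, 320 nM

Of the compounds shown here, two have been measured in an assay on C6 glioma cells for displacement of a labelled ligand from sodium- and chloride-dependent glycine transporter 1 (Rattus norvegicus), read by scintillation counting, with stated times of 30 min and 10 min; a lower number here means a stronger inhibitor, a higher number a weaker inhibitor. Compound 1 gives 860 nM, while compound 2 gives 320 nM, the lower of the two numbers and a gap beyond the usual scatter. Compound 3 `CCc1nnc(-c2ccc(-c3ccccc3)cc2)n1-c1cccc(COC)c1C` differs from compound 2 only by methoxymethyl in place of amino on an aromatic carbon. Among the compounds with values here, no measured pair shows this exact change, so the expected step is small and without a clear direction, likely within the scatter. Compound 3 is therefore estimated at 350 nM, with a range from 120 nM to 1000 nM. The step this estimate implies, a 1.1-fold higher number from compound 2 to compound 3 (0.04 log units; within the scatter), is expected to stay within the scatter.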

Compound 3, half-maximal inhibitory concentration: 2400 nM
For compound 3 the middle estimate is 6.9-fold (0.84 log units) below the measured one; measured number outside the range, above it.
By their numbers in this assay, from the lowest: compound 2; then compound 1; then compound 3.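

In this assay this aromatic carbon, ortho to a methyl group, proves sensitive to the change: methoxymethyl in place of amino gives a 7.5-fold higher number from compound 2 to compound 3 (0.88 log units; beyond the scatter) and makes the inhibitor clearly weaker. The swap removes the hydrogen-bond donor and adds heavy atoms, and this single pair cannot separate those two differences. Nothing measured here explains the drop. Hydroxyl or methylamino on this carbon could help show whether the amino group itself matters, or whether methoxymethyl is simply poorly accepted here.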